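A Branched Pyridine Swap on a Flat Pair

The source may hold more compounds than are shown below. What is called first, only, known or untested is meant among the compounds shown, and "the series" means these compounds.

Measured in a functional assay for inhibition, with Homo sapiens as the target; on this read-out higher numbers stand for weaker inhibition and lower numbers for stronger inhibition:
Compound 1 `Cc1nc2ccc(COc3ccc4c(c3)c(SC(C)(C)C)c(CC(C)(C)C(=O)O)n4Cc3ccc(Cl)cc3)cc2s1`: 6 nM
Compound 2 `CC(C)(C)Sc1c(CC(C)(C)C(=O)O)n(Cc2ccc(Cl)cc2)c2ccc(OCc3ccncc3)cc12`: 6 nM

Among the compounds with values here, compound 2, at 6 nM, stands level with compound 1, the only other compound measured so far. The next compound to be tested is compound 3 `CC(COc1ccc2c(c1)c(SC(C)(C)C)c(CC(C)(C)C(=O)O)n2Cc1ccc(Cl)cc1)c1ccccn1`. Its structural change from compound 2 is 1-(pyridin-2-yl)ethyl in place of pyridin-4-yl on a saturated chain carbon bound to an oxygen on an aromatic ring.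

Within the data shown here, one measured step bears on this, and it sits at the same place: no change at the digits printed from compound 1 to compound 2 (within the scatter), with pyridin-4-yl in place of 2-methyl-1,3-benzothiazol-6-yl. That exchange stayed within the scatter. Among the measured compounds shown here, no measured compound carries the 1-(pyridin-2-yl)ethyl group, so the data offer only this indirect guide, and the uncertainty is wide, chiefly toward weaker inhibition. No change beyond the scatter is expected, and the expected step is a 1.3-fold higher number from compound 2 to compound 3 (0.12 log units; within the scatter). For compound 3 the estimated value in this assay is 8 nM, with an expected range from 3 nM to 25 nM.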

Compound 3, half-maximal inhibitory concentration: 4 nM
Estimate against measurement, compound 3: 2.0-fold (0.30 log units) above, and the stated range covers the measured number.
By their numbers in this assay, from the lowest: compounds 3, 1 and 2 (each within the scatter of the next).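

In this assay, the 1-(pyridin-2-yl)ethyl group, with 8 heavy atoms where pyridin-4-yl has 6, holds the level on a saturated chain carbon bound to an oxygen on an aromatic ring: the record gives a 1.5-fold lower number from compound 2 to compound 3 (0.18 log units; within the scatter) and a 1.5-fold lower number from compound 1 to compound 3 (0.18 log units; within the scatter). Within the data shown here, the first two compounds showed only that one aromatic ring group could stand in for another at this place, whereas compound 3 shows that the read-out also stays within the scatter when a pyridine arrives as part of the larger, branched 1-(pyridin-2-yl)ethyl group. The compounds shown offer no measurement that accounts for this flat result.

Compound 3 alters both the pyridine attachment and the carbon chain in a single step, so the compounds shown cannot separate the two changes, and plain pyridin-2-yl would be needed to tell them apart. Every group compared here also carries an aromatic ring, which leaves open whether the same level would hold for a group without one, such as a simple amine or a carboxylic acid.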